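The source may hold more compounds than are shown below. What is called first, only, known or untested is meant among the compounds shown, and "the series" means these compounds.

Three compounds share one core and differ at a single group. Compound 1 `CCc1cc(C(C)=O)c(O)cc1OCCCCC#N` carries a methyl on a saturated chain carbon bound to an aromatic carbon, compound 2 `CC(=O)c1cc(CC2CO2)c(OCCCCC#N)cc1O` has an oxiran-2-yl there, and compound 3 `C=CCc1cc(C(C)=O)c(O)cc1OCCCCC#N` a vinyl. In an assay on isolated protein for inhibition of leukotriene B4 receptor 1 (Homo sapiens), tested at 10 uM (on this read-out higher numbers stand for more inhibition at the one concentration tested (going by the name of the read-out) and lower numbers for less inhibition), compound 1 gives 92%, compound 2 gives 62% and compound 3 gives 92%. The steps show a number 30 percentage points lower from compound 1 to compound 2 (beyond the scatter), no change at the digits printed from compound 1 to compound 3 (within the scatter) and a number 30 percentage points higher from compound 2 to compound 3 (beyond the scatter), so compound 3 stands level with compound 1, and together they give the highest of the three numbers. Compound 4 `C=CCc1cc(C(C)=O)c(O)cc1OCCCCCCCCCCC#N` keeps the vinyl and alters the other side of the core: 6-cyanohexyl in place of cyano on a saturated chain carbon, four bonds along the chain from an oxygen on an aromatic ring. Going by the values given here, none of the measured steps touches this chain, since all three change only the group on the saturated chain carbon bound to an aromatic carbon. There is thus no shown step to set the size or direction of the change in this assay, and the expectation is a step of a number 7 percentage points lower from compound 3 to compound 4 (within the scatter), within the scatter. Compound 4 is therefore expected to give about 85%, between 62% and 98%.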

Compound 4, a percentage reported as inhibition, at one concentration (the size of the read-out at that concentration, not a potency): 50%
Compound 4: the middle estimate sits 35 percentage points above what was measured, and the stated range ends above it.
By their numbers in this assay, from the lowest: compound 4; then compound 2; then compounds 1 and 3 (each within the scatter of the next).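

In this assay, the chain carrying the nitrile proves to be a sensitive part of the molecule: placing 6-cyanohexyl in place of cyano, on a saturated chain carbon four bonds along the chain from an oxygen on an aromatic ring, gives a number 42 percentage points lower from compound 3 to compound 4 (beyond the scatter). The earlier compounds shown here all kept this chain and varied only the group on the other side of the core, so they could not show that extending it costs this much inhibition while the vinyl stays in place. Nothing available explains why the longer chain goes with less inhibition.

On these data alone, with only these two chain lengths, it remains open whether inhibition falls gradually or suddenly as the chain grows. It is also unclear whether a chain of intermediate length, or one ending in a carboxylic acid or an amine instead of the nitrile, would retain inhibition.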